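A few compounds are considered here, and "the series" means these few. Any claim that something is new, unique, unknown or untested is made for them only; others in the source may bear on it.

Measured in a functional assay on HL-60 cells (Homo sapiens) for antiproliferative activity, read by MTT assay, with a stated time of 24 h; on this read-out lower numbers stand for stronger inhibition and higher numbers for weaker inhibition:
- Compound 1 (`CCCCc1oc2ccccc2c1C(=O)c1ccc(OCCCC(=O)N2CCCC2)cc1`): 29900 nM
- Compound 2 (`CCCCc1oc2ccccc2c1C(=O)c1ccc(OCCCC(=O)N2CCCCC2)cc1`): 31900 nM
- Compound 3 (`CCCCc1oc2ccccc2c1C(=O)c1cc(I)c(OCCCN2CCCCC2)c(I)c1`): 11500 nM

Of these three, compound 3 gives the lowest number, and compound 1 and compound 2 both lie above it by more than the usual scatter. Compound 4 (`CCCCc1oc2ccccc2c1C(=O)c1cc(I)c(OCCCNCc2ccccc2)c(I)c1`) has not yet been measured. It departs from compound 3 by one change: benzylamino in place of piperidin-1-yl on a saturated chain carbon, three bonds along the chain from an oxygen on an aromatic ring.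

Going by the values given here, only one measured step bears on this change, and it is an indirect guide: a 1.1-fold higher number from compound 1 to compound 2 (0.03 log units; within the scatter). Among the compounds with values here, that step exchanges pyrrolidin-1-yl for piperidin-1-yl on a carbonyl carbon, not on a saturated chain carbon, and no measured compound carries benzylamino. The data therefore give no direction, and no step beyond the scatter is expected in this assay, although the uncertainty is wide.

The expected step is a 1.2-fold lower number from compound 3 to compound 4 (0.06 log units; within the scatter).

Compound 4 is estimated at 10000 nM, with an expected range of 4000 nM to 25000 nM.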

Compound 4, half-maximal inhibitory concentration: 4400 nM
Compound 4: middle estimate off by 2.3-fold (0.36 log units), on the high side, within the range that was stated.
By their numbers in this assay, from the lowest: compound 4; then compound 3; then compounds 1 and 2 (each within the scatter of the next).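

In this assay, benzylamino in place of piperidin-1-yl on a saturated chain carbon, three bonds along the chain from an oxygen on an aromatic ring, gives a 2.6-fold lower number from compound 3 to compound 4 (0.42 log units; beyond the scatter). Going by these compounds alone, the only earlier step, a 1.1-fold higher number from compound 1 to compound 2 (0.03 log units; within the scatter), exchanged one saturated ring for another on a carbonyl carbon and stayed within the scatter, whereas this step shows that the number at this position can move beyond the scatter when the amine group changes. No measurement shown accounts for this step.

This exchange alters the ring and the amine hydrogen together, and the compounds shown do not separate the two; cyclohexylmethylamino and N-benzyl-N-methylamino at the same place would each change only one. As far as these compounds go, it also remains open whether benzylamino would give a similar step on a core without the iodine atoms.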